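Benzofuran to furan swap at the five-membered ring position

A few compounds are considered here, and "the series" means these few. Any claim that something is new, unique, unknown or untested is made for them only; others in the source may bear on it.

Compound 2 `O=c1[nH]cnc2c1c(-c1cc3ccccc3o1)cn2[C@@H]1O[C@H](CO)[C@@H](O)[C@H]1O` stands at the upper edge of what a functional assay on HCT-116 cells (Homo sapiens), read by MTT assay, with a stated time of 72 h (a higher number here means a weaker inhibitor, a lower number a stronger inhibitor), can report: in this assay compound 2 gives > 20000 nM, which is a limit and not a number. Compound 1 `COc1nc(N)nc2c1c(-c1cc3ccccc3o1)cn2[C@@H]1O[C@H](CO)[C@@H](O)[C@H]1O` carries the same 1-benzofuran-2-yl group on a different core and also returns only a limit, as in this assay compound 1 gives > 20000 nM. Among the measured compounds shown here, the one numerical value belongs to compound 3 `Cc1ncnc2c1c(-c1ccsc1)cn2[C@@H]1O[C@H](CO)[C@@H](O)[C@H]1O`, which in this assay gives 1430 nM; both its core and its five-membered group differ from those of compound 2, so no single step joins the two. What the two limits share is stated by the limit of > 20000 nM in this assay, at which 2 of the 3 values shown sit.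

Compound 4 `O=c1[nH]cnc2c1c(-c1ccoc1)cn2[C@@H]1O[C@H](CO)[C@@H](O)[C@H]1O` is the next structure to be measured. furan-3-yl in place of 1-benzofuran-2-yl on an aromatic carbon

For the measured compounds named here, no measured pair isolates this change, and with compound 2 reported only as a limit the direction of any movement cannot be read from the numbers. The step from compound 2 to compound 4 is expected to be a number no higher from compound 2 to compound 4 (the limit leaves the size open), with a further limit the likeliest outcome. For compound 4 the estimated value is 20000 nM, with a range from 5000 nM to 60000 nM.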

Compound 4, half-maximal inhibitory concentration: 14800 nM
The estimate for compound 4 lay 1.4-fold (0.13 log units) above the measured number, within the range that was stated.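

With furan-3-yl in place of 1-benzofuran-2-yl on the aromatic carbon two ring bonds from the ring nitrogen, compound 4 gives 14800 nM in this assay, which places a structure with this core within the range the read-out can report as a number. As far as these compounds go, the change reads as an at least 1.3-fold lower number from compound 2 to compound 4 (0.13 log units; that floor lies within the scatter), and as the entry for compound 2 is a limit, this gives only a floor, so the true size of the step stays open and could be small or much larger. The new number therefore shows that this position can carry furan-3-yl with a measurable result, while the limit remains the reading for the benzofuran-bearing compounds: the limit of > 20000 nM in this assay, at which 2 of the 4 values shown sit.

Compound 3 and compound 4 differ in more than one place, so the compounds shown do not separate what the group at this position contributes from what the rest of the core contributes. From the compounds shown here alone, whether a phenyl ring at this carbon, or an amine or a carboxylic acid on the furan-3-yl group, would move the number on the core of compound 4 remains open.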